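Fluorine on the Phenyl Ketone of a Shared Core

A few compounds are considered here, and "the series" means these few. Any claim that something is new, unique, unknown or untested is made for them only; others in the source may bear on it.

Measured so far:
compound 1 `CCC(=O)c1ccc2c(c1)C(n1ccccc1=O)=CC(C)(C)O2`: 6.63
compound 2 `CC1(C)C=C(n2ccccc2=O)c2cc(C(=O)c3ccccc3)ccc2O1`: 6.61
compound 3 `COc1ccc(C(=O)c2ccc3c(c2)C(n2ccccc2=O)=CC(C)(C)O3)cc1`: 6.15

The three measured compounds share one core and differ only in the group on the carbonyl carbon. In a functional assay (aorta) with Rattus norvegicus as the target (on this read-out higher numbers stand for higher potency (the scale is a negative logarithm) and lower numbers for lower potency), compound 1 stands highest of the three numbers; compound 2 lies nearest, a number 0.02 log units lower from compound 1 to compound 2 (within the scatter), and compound 3 lies furthest, a number 0.48 log units lower from compound 1 to compound 3 (beyond the scatter).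

Compound 4 `CC1(C)C=C(n2ccccc2=O)c2cc(C(=O)c3ccccc3F)ccc2O1` has not yet been measured. Its change from compound 1 is 2-fluorophenyl in place of ethyl on a carbonyl carbon.

For the measured compounds named here, two measured steps bear on this change. Replacing ethyl with a plain phenyl cost nothing, a number 0.02 log units lower from compound 1 to compound 2 (within the scatter). Adding a methoxy to that phenyl on an aromatic carbon cost a modest amount, a number 0.46 log units lower from compound 2 to compound 3 (beyond the scatter), and the combined change to 4-methoxyphenyl read a number 0.48 log units lower from compound 1 to compound 3 (beyond the scatter). Going by the values given here, no measured compound carries fluorine, so the effect of that substituent is untested here. The author therefore expects compound 4 to land close to compound 2, with a small allowance for a drop of the kind seen with the methoxy substituent; the step of a number 0.13 log units lower from compound 1 to compound 4 (within the scatter) is expected to lie within or only just beyond the scatter.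

Compound 4 is estimated at 6.5, with a range from 6 to 7.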

Compound 4, logarithm of the reciprocal of the active concentration, log(1/C): 7.08
Compound 4: middle estimate off by 0.58 log units, on the low side, and the stated range ends below it.
By their numbers in this assay, from the lowest: compound 3; then compounds 2 and 1 (each within the scatter of the next); then compound 4.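

In this assay, a substituent on the phenyl ring of the ketone can raise the number as well as lower it: fluoro in place of hydrogen on an aromatic carbon gives a number 0.47 log units higher from compound 2 to compound 4 (beyond the scatter), whereas the methoxy of compound 3 went the other way. Plain phenyl had only matched ethyl on the carbonyl carbon, but 2-fluorophenyl gives a number 0.45 log units higher from compound 1 to compound 4 (beyond the scatter), and its replacement of 4-methoxyphenyl gives a number 0.93 log units higher from compound 3 to compound 4 (beyond the scatter), the widest step among the four compounds, so this position separates these aryl ketones more sharply than the first three compounds showed. Nothing available explains the gain, which therefore stands as an observation only.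

The compounds shown leave open whether the gain belongs to fluorine itself or to the place it holds in 2-fluorophenyl, since 4-methoxyphenyl differs from it in both the group and its number on the ring. They also leave open how a chlorine, a methyl group or a second fluorine on the same phenyl ring would read, and so whether fluorine is unusual here or one of several groups that raise the number.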